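The source may hold more compounds than are shown below. What is called first, only, known or untested is meant among the compounds shown, and "the series" means these compounds.

Measured in a functional assay on HCT-116 cells (Homo sapiens) for antiproliferative activity, read by MTT assay, with a stated time of 72 h; on this read-out higher numbers stand for weaker inhibition and lower numbers for stronger inhibition:
- compound 1 `COc1cc(CCc2ccccn2)cc(OC)c1O` at 3060 nM
- compound 2 `COc1cc(CCc2ccccc2)cc(OC)c1O` at 530 nM
- compound 3 `COc1cc(CCc2ccc(F)cc2)cc(OC)c1O` at 1190 nM

Compound 3 at 1190 nM stands second highest of the three numbers, with compound 2 nearest and compound 1 furthest. Compound 4 `COc1cc(CCc2ccc(Br)cc2)cc(OC)c1O` differs from it by bromo in place of fluoro on an aromatic carbon (bromo in place of fluoro on an aromatic carbon, para to a large group). The most relevant measured step is a 2.2-fold higher number from compound 2 to compound 3 (0.35 log units; beyond the scatter) for fluoro in place of hydrogen on an aromatic carbon. The step of a 5.8-fold lower number from compound 1 to compound 2 (0.76 log units; beyond the scatter) exchanges pyridin-2-yl for phenyl and bears little on this change. Among the measured compounds shown here, no bromo compound has been measured. In this assay the expected step is a 1.1-fold lower number from compound 3 to compound 4 (0.03 log units; within the scatter) and is not expected to exceed the scatter. The estimate for compound 4 is 1100 nM with an expected range of 450 nM to 2700 nM in this read-out.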

Compound 4, half-maximal inhibitory concentration: 15900 nM
Compound 4: the middle estimate sits 14-fold (1.16 log units) below what was measured; the measured number lies above the stated range.
By their numbers in this assay, from the lowest: compound 2; then compound 3; then compound 1; then compound 4.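

In this assay, with a 13-fold higher number from compound 3 to compound 4 (1.13 log units; beyond the scatter) for bromo in place of fluoro, the choice of halogen para to a large group matters far more than the fluoro result alone suggested. Against hydrogen at the same place, a 30-fold higher number from compound 2 to compound 4 (1.48 log units; beyond the scatter) is a much larger step than the one fluoro gave, so among hydrogen, fluoro and bromo, hydrogen gives the lowest number and bromo the highest. Nothing available here explains the size of the bromo step.

Still open, going by these compounds, is where a chloro, methoxy or amine at this place would fall relative to these three. Also open, on these data alone, is whether any group there gives a lower number than compound 2 does.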